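Propyl to butyl on the shared core: cytotoxicity notes

This account rests on a few compounds, and the source may have more. Where it says the series, first, only, none or still open, it means among the compounds named here.

The three measured compounds are followed in an ADME assay on J774.1 cells (Mus musculus) for cytotoxicity, read by resazurin assay, with a stated time of 48 h; on this read-out higher numbers stand for weaker inhibition and lower numbers for stronger inhibition. Compound 1 `CCCCn1cc(C(=O)NCc2ccccc2)c(=O)c2cc(F)c(-c3ccccc3)cc21` is reported only as a limit of the assay, > 100000 nM. Compound 2 `CCCn1cc(C(=O)O)c(=O)c2cc(F)c(Cl)cc21` is likewise reported only as a limit of the assay, > 100000 nM. Compound 3 `COc1ccc(CNC(=O)c2cn(C3CC3)c3cc(N4CCC(C(N)=O)CC4)c(F)cc3c2=O)cc1` also reaches only a limit of the assay, > 100000 nM. Compound 2 therefore stands with both others at the limit of > 100000 nM in this assay, at which 3 of the 3 values shown sit, so none of the three can be set above or below another on the numbers shown.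

Compound 4 `CCCCn1cc(C(=O)O)c(=O)c2cc(F)c(Cl)cc21` remains to be measured in this assay. It differs from compound 2 by methyl in place of hydrogen on a saturated chain carbon, three bonds along the chain from an aromatic nitrogen. For the measured compounds named here, no step between measured compounds that differ in one place is available, so the size of such a change in this assay has no direct precedent here. The expected step is a step that the limit leaves unreadable from compound 2 to compound 4, that is, none beyond the usual scatter. Compound 4 is estimated at 150000 nM, with a range from 70000 nM to 400000 nM, and is expected most likely to come back again as a limit only.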

Compound 4, half-maximal inhibitory concentration: > 100000 nM
Compound 4 was reported as a limit; the forecaster's own chance of this, stated with the estimate: 90%; the middle value is on the limit's open side.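

No step can be read from compound 2 to compound 4, since both are reported only as limits of the assay: the limit of > 100000 nM in this assay, at which 4 of the 4 values shown sit. The compounds shown leave open how far each lies beyond that limit, and whether methyl in place of hydrogen on the chain alters cytotoxicity at all.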